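Phenylethynyl in place of methyl on the shared core

This account rests on a few compounds, and the source may have more. Where it says the series, first, only, none or still open, it means among the compounds named here.

In a physicochemical assay for solubility, read by nephelometry, measured as kinetic solubility, at pH 6.5, tested at 10 mg/mL (on this read-out lower numbers stand for lower solubility and higher numbers for higher solubility), compound 2 `Cc1ccnc(NC(=O)c2ccccc2C)c1` reads 25 ug/mL and stands level with compound 1 `Cc1ccccc1C(=O)Nc1cc(C#N)ccn1` at 25 ug/mL on the same read-out. The next change gives compound 3 `Cc1ccccc1C(=O)Nc1cc(C#Cc2ccccc2)ccn1` and is counted as 2-phenylethynyl in place of methyl on an aromatic carbon in the series: 2-phenylethynyl in place of methyl on an aromatic carbon. Among the measured compounds shown here, one measured step bears on it, no change at the digits printed from compound 1 to compound 2 (within the scatter) for methyl in place of cyano, and that step lies within the scatter. That step brings in no ring, so it is a weak guide here. A lower reading is still expected, a judgement resting on the structural change alone. The expected step is a 4.2-fold lower number from compound 2 to compound 3 (0.62 log units; beyond the scatter) in this assay as a working estimate. For compound 3 the estimated value is 6 ug/mL with an expected range of 1.5 ug/mL to 20 ug/mL for now.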

Compound 3, solubility: < 1.6 ug/mL
Compound 3 was reported as a limit; the forecaster's own chance of this, stated with the estimate: 15%; middle value at least 3.7-fold (0.57 log units) away from the limit.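

In this assay the position opposite the ring nitrogen now proves sensitive to the group it carries: 2-phenylethynyl in place of methyl gives an at least 15-fold lower number from compound 2 to compound 3 (1.19 log units; beyond the scatter), and 2-phenylethynyl in place of cyano gives an at least 15-fold lower number from compound 1 to compound 3 (1.19 log units; beyond the scatter). Methyl and cyano had not separated, with no change at the digits printed from compound 1 to compound 2 (within the scatter), so of the three groups at this position only 2-phenylethynyl, which enters with a six-membered aromatic ring and a triple bond, gives a step beyond the scatter. The reading of compound 3 is a limit and not a number: the limit of < 1.6 ug/mL in this assay, at which 1 of the 3 values shown sits.

The compounds shown leave open how far the true value of compound 3 lies past that limit, and whether the ring or the triple bond carries the step. Also open, on these data alone, is whether an amine or a carboxylic acid on the 2-phenylethynyl group would change the reading.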